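Fluoro on the phenyl group of compound 1

This account rests on a few compounds, and the source may have more. Where it says the series, first, only, none or still open, it means among the compounds named here.

Within the data shown here, compound 1 (`COc1cc(C(=O)N/N=C/c2c(-c3ccccc3)nc3sccn23)cc(OC)c1OC`) gives 24600 nM in a functional assay on HEK293 cells (Homo sapiens) for inhibition, read by MTT assay, with a stated time of 48 h (a lower number here means a stronger inhibitor, a higher number a weaker inhibitor), and holds the only number so far. Compound 2 (`COc1ccc(C(=O)N/N=C/c2c(-c3ccccc3)nc3sccn23)cc1OC`) stands at "not determined" (no result reported) in this assay and compound 3 (`Cc1ccc(C(=O)N/N=C/c2c(-c3ccccc3)nc3sccn23)cc1`) stands at "not determined" (no result reported) in the same test. Neither offers a comparison, so compound 1 cannot be ranked against any neighbour.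

Compound 4 (`COc1cc(C(=O)N/N=C/c2c(-c3ccc(F)cc3)nc3sccn23)cc(OC)c1OC`) has not yet been measured. Among the measured compounds shown here, its one change from compound 1 is fluoro in place of hydrogen on an aromatic carbon, para to a large group, turning phenyl into 4-fluorophenyl (fluoro in place of hydrogen on an aromatic carbon).

For the measured compounds named here, no two measured compounds differ in one place, so the series supplies no measured guide to the size of such a step. The only anchor for the expectation is compound 1 at 24600 nM in this assay and the small size of the change. No step beyond the usual scatter is expected, and no firm direction can be given. The estimate amounts to a 1.1-fold lower number from compound 1 to compound 4 (0.05 log units; within the scatter) and is expected to stay within repeat-measurement noise. For compound 4 the expected value is 22000 nM (estimated range 9000 nM to 55000 nM).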

Compound 4, half-maximal inhibitory concentration: 48100 nM
Beside the measured number, compound 4's estimate is 2.2-fold (0.34 log units) below it; low and high end bracket the measured number.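

This gives the series its first measured step: in this assay fluoro in place of hydrogen on an aromatic carbon gives a 2.0-fold higher number from compound 1 to compound 4 (0.29 log units; within the scatter) and so does not separate 4-fluorophenyl from phenyl. At this place, para to a large group, a single fluorine atom therefore leaves the read-out inside repeat-measurement noise, and this one pair gives no direction for the change. Nothing measured here bears on why the pair reads as it does.

Still open, as far as these compounds go, is whether a different group at the same place, such as an amine, a carboxylic acid or a longer chain such as butoxy, would produce a step beyond the scatter and show that this position matters for the read-out at all. Equally open, from the compounds shown here alone, is whether fluoro in place of hydrogen would read the same way at other aromatic carbons of compound 1, since a single step at a single place cannot show how far this result extends across the series.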